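A few compounds are considered here, and "the series" means these few. Any claim that something is new, unique, unknown or untested is made for them only; others in the source may bear on it.

Values in a functional assay on G-361 cells (Homo sapiens) for inhibition, with a stated time of 72 h; on this read-out lower numbers stand for stronger inhibition and higher numbers for weaker inhibition:
- compound 1 `NC1CCC(Nc2nc(NCc3ccc(Br)cc3)c3ncn(C4CCCC4)c3n2)CC1`: 1480 nM
- compound 2 `NC1CCC(Nc2nc(NCc3ccc(-c4ccsc4)cc3)c3ncn(C4CCCC4)c3n2)CC1`: 570 nM
- compound 3 `NC1CCC(Nc2nc(NCc3ccc(-c4ccccc4)nc3)c3ncn(C4CCCC4)c3n2)CC1`: 895 nM

Compound 3, at 895 nM, stands within the scatter of both other compounds. The two steps that reach it are a 1.7-fold lower number from compound 1 to compound 3 (0.22 log units; within the scatter) and a 1.6-fold higher number from compound 2 to compound 3 (0.20 log units; within the scatter). Only a 2.6-fold lower number from compound 1 to compound 2 (0.41 log units; beyond the scatter) lies beyond the scatter, and that step is modest.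

Compound 4 `NC1CCC(Nc2nc(NCc3ccc(-c4cccc(F)c4)nc3)c3ncn(C4CCCC4)c3n2)CC1` keeps everything in compound 3 except one position: fluoro in place of hydrogen on an aromatic carbon, turning phenyl into 3-fluorophenyl (fluoro in place of hydrogen on an aromatic carbon). The new group sits on a six-membered aromatic ring of carbon only, meta to a large group.

Among the measured compounds shown here, no measured step makes this exchange, so the evidence is indirect. Even the exchanges of a whole aromatic group gave only a 1.7-fold lower number from compound 1 to compound 3 (0.22 log units; within the scatter) and a 1.6-fold higher number from compound 2 to compound 3 (0.20 log units; within the scatter), and the exchange of bromo for thiophen-3-yl gave a 2.6-fold lower number from compound 1 to compound 2 (0.41 log units; beyond the scatter). A change confined to fluoro in place of hydrogen is therefore expected to give no step beyond the scatter, and no direction can be argued from these data.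

The expected outcome is a 1.1-fold lower number from compound 3 to compound 4 (0.05 log units; within the scatter). For compound 4 the estimated value is 800 nM. For compound 4 the estimated range runs from 380 nM to 1600 nM.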

Compound 4, half-maximal inhibitory concentration: 49 nM
For compound 4 the middle estimate is 16-fold (1.21 log units) above the measured one; measured number below the stated range.
By their numbers in this assay, from the lowest: compound 4; then compounds 2, 3 and 1 (each within the scatter of the next, the first and the last beyond it).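

In this assay, among the compounds shown here, the single exchange of hydrogen for fluoro gives an 18-fold lower number from compound 3 to compound 4 (1.26 log units; beyond the scatter) on an aromatic carbon of a six-membered aromatic ring of carbon only, meta to a large group, so this position responds strongly to a change of one heavy atom. For the compounds shown here, the size of the exchange does not track the size of the step: replacing whole groups gave only a 1.7-fold lower number from compound 1 to compound 3 (0.22 log units; within the scatter) and a 1.6-fold higher number from compound 2 to compound 3 (0.20 log units; within the scatter) and at most a 2.6-fold lower number from compound 1 to compound 2 (0.41 log units; beyond the scatter) as the one step beyond the scatter, all well short of what phenyl to 3-fluorophenyl gives. No measurement at hand bears on what lies behind this gain.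

The compounds shown leave open whether the gain belongs to fluoro itself or to this place on the ring, a question that chloro, methoxy or a nitrile on the same carbon, and fluoro on the other carbons of the phenyl, would help to settle. Also open, on these data alone, is whether the gain carries over when 3-fluorophenyl takes the place of thiophen-3-yl in compound 2.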